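This account rests on a few compounds, and the source may have more. Where it says the series, first, only, none or still open, it means among the compounds named here.

Compound 1 `Cc1ccccc1S(=O)(=O)c1ccc(CNC(=O)c2cc3cnccc3[nH]2)cc1` is an amide in which a sulfonyl-bearing benzylic group is joined to the shared core, and in an assay for inhibition of Nicotinamide phosphoribosyltransferase (Homo sapiens), read by mass spectrometry, with stated times of 15 min and 30 min (a lower number here means a stronger inhibitor, a higher number a weaker inhibitor), compound 1 gives 12 nM. Compound 2 `O=C(NCc1ccc(S(=O)(=O)N2CCCCC2)cc1)c1cc2cnccc2s1` differs from compound 1 in both the core and the sulfonyl group, and in this assay compound 2 gives 150 nM. Compound 3 `O=C(NCc1ccc(S(=O)(=O)c2ccccc2)cc1)c1ccc2cnccc2c1` gives > 10000 nM in this assay, which is a limit of the assay rather than a number, as told by the limit of > 10000 nM in this assay, at which 1 of the 3 values shown sits. Among the two real numbers, compound 1 stands lowest, with compound 2 the nearest. Compound 4 `O=C(NCc1ccc(S(=O)(=O)c2cccc(C(F)(F)F)c2)cc1)c1cc2cnccc2[nH]1` has not yet been measured; it differs from compound 1 by 3-(trifluoromethyl)phenyl in place of 2-methylphenyl on a sulfonyl sulfur. Among the measured compounds shown here, no measured pair tests this change, so a step no larger than the scatter is expected, if anything toward a slightly higher number. For compound 4 the estimate is 20 nM, expected to lie between 7 nM and 60 nM. The expected step from compound 1 to compound 4 is a 1.7-fold higher number from compound 1 to compound 4 (0.22 log units; within the scatter).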

Compound 4, half-maximal inhibitory concentration: 8 nM
Beside the measured number, compound 4's estimate is 2.5-fold (0.40 log units) above it; the measured number falls inside the stated range.
By their numbers in this assay, from the lowest: compounds 4 and 1 (each within the scatter of the next); then compound 2. At a limit, above all of these: compound 3.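

The change of the substituted phenyl ring on the sulfonyl sulfur gives, in this assay, a 1.5-fold lower number from compound 1 to compound 4 (0.18 log units; within the scatter), so the two compounds cannot be told apart. This shows that the sulfonyl sulfur of this series can carry either of these substituted phenyl rings, the second with more heavy atoms, and the number stays within the usual scatter. Nothing measured here accounts for this result:.

The compounds shown leave open how a carboxylic acid or a simple amine on the phenyl ring would fare at this place. They also leave open whether a longer chain could stand in for the ring on the sulfonyl sulfur.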